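Methoxy for phenyl on the ketone-bearing ring

This account rests on a few compounds, and the source may have more. Where it says the series, first, only, none or still open, it means among the compounds named here.

Compound 1: `CCOC(=O)c1ccc(Nc2ccnc(SCC(=O)c3ccc(C#N)cc3)n2)cc1` gives 52% in a functional assay on UO-31 cells (Homo sapiens) for inhibition, read by sulforhodamine B assay, with a stated time of 48 h, tested at 10 uM; on this read-out higher numbers stand for more inhibition of growth at the one concentration tested and lower numbers for less inhibition of growth.
Compound 2: `CC(=O)c1cccc(Nc2ccnc(SCC(=O)c3ccc(-c4ccccc4)cc3)n2)c1` gives 40% in this assay.

Of the compounds shown here, two have been measured here. Compound 1 is the higher of the pair; compound 2 stands lowest of the two numbers, and its nearest neighbour, compound 1, lies higher by a gap that is beyond the scatter of repeated measurements. The two compounds differ in more than one place. Of this pair only what its two values show can be said.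

Compound 3 is `COc1ccc(C(=O)CSc2nccc(Nc3cccc(C(C)=O)c3)n2)cc1` and has not yet been measured. It differs from compound 2 in one place: methoxy in place of phenyl on an aromatic carbon. Going by the values given here, no measured pair shows the effect of this kind of exchange, so there is no basis for expecting a large step in either direction. The change is expected to give a step of a number 2 percentage points lower from compound 2 to compound 3 (within the scatter), which is within the scatter. For compound 3 the expected value is 38%, with a range from 20% to 58%.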

Compound 3, percent growth inhibition at one concentration: 55%
The estimate for compound 3 lay 17 percentage points below the measured number, within the range that was stated.
By their numbers in this assay, from the lowest: compound 2; then compounds 1 and 3 (each within the scatter of the next).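

In this assay, going by these compounds alone, the exchange of phenyl for methoxy gives a number 15 percentage points higher from compound 2 to compound 3 (beyond the scatter), the first step that can be tied to a single place, since compound 1 and compound 2 differ in more than one. It shows that, at this place para to a large group, the phenyl ring of 6 heavy atoms is not needed for growth inhibition at the one concentration tested, as the methoxy group of 2 heavy atoms stands higher. The exchange removes a ring, reduces the heavy atoms and adds a hydrogen-bond acceptor all at once, and no available measurement separates these changes or accounts for the step.

This single pair leaves open whether the step would hold on a different core, such as that of compound 1, which carries a nitrile at this place and differs from compound 3 elsewhere too. It also leaves open how an amine, a hydroxyl group or a longer ether such as ethoxy would fare at the same place, and so whether the hydrogen-bond acceptor or the smaller size goes with the higher number.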